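Benzyl replacement on the shared core, compound 3 to compound 4

The compounds below may be only part of what the source reports. "The series", "measured", "known", "first", "only" and "open" are said of these compounds alone.

compound 1 `Cc1cccc(Cc2c(C(N)=O)c3cc(O[C@H]4CC[C@@H](C(=O)O)CC4)ccc3n2C)c1` — 600 nM
compound 2 `Cc1cccc(Cc2nc3ccc(O[C@H]4CC[C@@H](C(=O)O)CC4)cc3n2C)c1` — > 200000 nM (limit)
compound 3 `Cc1ccccc1Cc1nc2cc(O[C@H]3CC[C@@H](C(=O)O)CC3)ccc2n1C` — 7800 nM

In an assay on isolated protein for inhibition of Long-chain-fatty-acid--CoA ligase 1 (Homo sapiens), read by mass spectrometry, with a stated time of 90 min, in the presence of a further agent that is not named here (on this read-out higher numbers stand for weaker inhibition and lower numbers for stronger inhibition), compound 1 gives 600 nM. For compound 2 the assay reports no number but only a limit, > 200000 nM (the limit of > 200000 nM in this assay, at which 1 of the 3 values shown sits). Compound 3 gives 7800 nM, the higher of the two numbers shown; the nearest value is that of compound 1, which lies clearly lower, beyond the scatter. Compound 2 and compound 3 differ in more than one place, so their values show only that one is a limit and the other a number.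

Compound 4 `Cn1c(Cc2cccc(C#N)c2)nc2cc(O[C@H]3CC[C@@H](C(=O)O)CC3)ccc21` differs from compound 3 by 3-cyanophenyl in place of 2-methylphenyl on a saturated chain carbon bound to an aromatic carbon. Among the compounds with values here, no measured pair isolates this change on this core, so there is no step to lean on. The expectation is a step from compound 3 to compound 4 of a 1.3-fold higher number from compound 3 to compound 4 (0.11 log units; within the scatter), not clearly beyond the scatter in either direction. Compound 4 is therefore expected to give about 10000 nM, with a range from 2000 nM to 50000 nM.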

Compound 4, half-maximal inhibitory concentration: 51000 nM
The estimate for compound 4 lay 5.1-fold (0.71 log units) below the measured number; measured number above the stated range.
By their numbers in this assay, from the lowest: compound 1; then compound 3; then compound 4. At a limit, above all of these: compound 2.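

In this assay, 3-cyanophenyl in place of 2-methylphenyl on a saturated chain carbon bound to an aromatic carbon gives a 6.5-fold higher number from compound 3 to compound 4 (0.82 log units; beyond the scatter), the only single-place step shown, so inhibition on the shared core responds to what the benzyl ring carries. The step runs towards weaker inhibition, which shows that this nitrile-bearing benzyl group does not match the 2-methylbenzyl group here, but the identity of the ring substituent and its place on the ring change together, and the step cannot be assigned to either alone. No available evidence bears on the origin of this step.

Still open, on these data alone, is how plain benzyl would compare on the shared core. Also open, as far as these compounds go, is whether a methoxy group or a chlorine on the benzyl ring would follow the methyl group or the nitrile.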